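From methoxy to 1-hydroxyethyl: compound 3 and compound 4

The source may report more compounds than this note shows. Statements on the series, on what has been measured and on what is new or still open speak of the compounds shown alone.

Compound 1 `CCCCNc1nc(N)ncc1OCC`: > 25000 nM
Compound 2 `CC(C)CCNc1nc(N)nc2ccccc12`: > 25000 nM
Compound 3 `CCCCNc1nc(N)nc2ccc(OC)cc12`: > 18000 nM

All three entries come from an ADME assay on HEK293 cells (Homo sapiens) for cytotoxicity, with a stated time of 6 h (a higher number here means that more compound is tolerated, a lower number that less compound is tolerated), and each is a limit, not a number. Compound 3, the starting point here, stands at > 18000 nM, which is only a limit. Compound 4 `CCCCNc1nc(N)nc2ccc(C(C)O)cc12` carries 1-hydroxyethyl in place of methoxy on an aromatic carbon. For the measured compounds named here, no measured pair of compounds shows this change, so its size in this assay can only be expected, and no shift beyond the scatter is foreseen in either direction. The estimated change is a step that the limit leaves unreadable from compound 3 to compound 4. For compound 4 the estimated value is 25000 nM, with an expected range from 10000 nM to 50000 nM.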

Compound 4, half-maximal cytotoxic concentration: > 18000 nM
Compound 4 gave a limit, no number; the forecaster's own chance of this, stated with the estimate: 85%; the middle value lies beyond the limit too.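

Compound 3 gives > 18000 nM, which is a limit. Compound 4 gives > 18000 nM, again a limit, so no step can be read between compound 3 and compound 4. The compounds shown leave open whether 1-hydroxyethyl in place of methoxy changes tolerance at all.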